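The compounds below may be only part of what the source reports. "The series", "measured", "known", "first", "only" and "open" are said of these compounds alone.

Among the measured compounds shown here, compound 2 `O=C(/C=C/c1ccc2c(c1)B(O)OC2)c1ccc(O)cc1` is the weaker of the two compounds measured so far. For the measured compounds named here, in a functional assay on SK-OV-3 cells (Homo sapiens) for cytotoxicity, read by MTT assay, with a stated time of 48 h (a lower number here means a stronger inhibitor, a higher number a weaker inhibitor), compound 2 gives 13000 nM, while compound 1 `O=C(/C=C/c1ccc2c(c1)B(O)OC2)c1ccc(I)cc1` gives 4200 nM; the only step so far, a 3.1-fold higher number from compound 1 to compound 2 (0.49 log units; beyond the scatter), sets compound 2 as the higher of the two numbers. Compound 3 `Cc1cccc(C(=O)/C=C/c2ccc3c(c2)B(O)OC3)c1` has not yet been tested in this assay. Relative to compound 2 it carries 3-methylphenyl in place of 4-hydroxyphenyl on a carbonyl carbon, so the hydrogen-bond donor and acceptor of the 4-hydroxyphenyl are gone and a methyl-bearing ring stands in its place. Going by the values given here, the one measured step bears on this only indirectly: in a 3.1-fold higher number from compound 1 to compound 2 (0.49 log units; beyond the scatter) a hydroxy arriving in place of iodo went with a modest rise, and compound 3 now moves away from that hydroxy again. On that basis compound 3 is expected to fall back toward the number of compound 1, giving a step of a 2.2-fold lower number from compound 2 to compound 3 (0.34 log units; beyond the scatter) in this assay. The estimate for compound 3 is therefore 6000 nM, with a range from 2500 nM to 16000 nM.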

Compound 3, half-maximal inhibitory concentration: 2900 nM
Compound 3: middle estimate off by 2.1-fold (0.32 log units), on the high side, and the stated range covers the measured number.
By their numbers in this assay, from the lowest: compounds 3 and 1 (each within the scatter of the next); then compound 2.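

The 4-hydroxyphenyl on the carbonyl carbon can give way to 3-methylphenyl with a 4.5-fold lower number from compound 2 to compound 3 (0.65 log units; beyond the scatter) in this assay, so the rise seen earlier with the hydroxy is not specific to a comparison with iodo. The two groups without the hydroxy cannot be told apart, with a 1.4-fold lower number from compound 1 to compound 3 (0.16 log units; within the scatter), and among these three compounds only compound 2, the one carrying the 4-hydroxyphenyl, stands apart beyond the scatter. Nothing measured here explains why the hydroxy-bearing ring gives the higher number.

On these data alone, the step from compound 2 to compound 3 alters both the group and its place on the ring at once, so it remains open whether the difference belongs to the loss of the hydroxy or to the move, and a 4-methylphenyl would help to separate the two. Also open, as far as these compounds go, is how a ring carrying an amine, a carboxylic acid or a methoxy group on the same carbonyl carbon would read in this assay.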